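This account rests on a few compounds, and the source may have more. Where it says the series, first, only, none or still open, it means among the compounds named here.

Measured compounds in a functional assay on SK-BR-3 cells (Homo sapiens) for antiproliferative activity, read by MTT assay, with a stated time of 72 h; on this read-out lower numbers stand for stronger inhibition and higher numbers for weaker inhibition:
- compound 1 `Cc1cc(NCCN(C)C)nc2ccc(NC(=O)c3ccc(Cl)c(Cl)c3)cc12`: 6670 nM
- compound 2 `CCc1ccc(C(=O)Nc2ccc3nc(N4CCN(CC)CC4)cc(C)c3c2)cc1`: 9850 nM
- compound 3 `CCN1CCN(c2cc(C)c3cc(NC(=O)c4ccc(Cl)cc4)ccc3n2)CC1`: 3020 nM

Compound 3 gives the lowest of the three numbers in this assay. Compound 1 is its nearest neighbour, a gap beyond the scatter, and compound 2 lies furthest from it. Among the compounds with values here, the one step measured between two compounds that differ in a single place is a 3.3-fold lower number from compound 2 to compound 3 (0.51 log units; beyond the scatter), a modest change at the aromatic carbon of the carbonyl-bearing phenyl ring.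

Compound 4 `CCN1CCN(c2cc(C)c3cc(NC(=O)c4ccc(F)cc4)ccc3n2)CC1` is not yet measured. It differs from compound 3 as follows: fluoro in place of chloro on an aromatic carbon. Within the data shown here, no measured pair exchanges one halogen for another, so nothing bears directly on this step. The step from compound 2 to compound 3 shows that a change at this same aromatic carbon can move the number beyond the scatter, but it involved a different leaving group. Given that, the expectation for compound 4 is a number close to that of compound 3, possibly slightly higher, with the step expected to be a 1.5-fold higher number from compound 3 to compound 4 (0.17 log units; within the scatter). The estimate for compound 4 in this assay is 4500 nM, with a range from 1800 nM to 11000 nM.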

Compound 4, half-maximal inhibitory concentration: 19800 nM
The estimate for compound 4 lay 4.4-fold (0.64 log units) below the measured number, and the stated range ends below it.
By their numbers in this assay, from the lowest: compound 3; then compounds 1, 2 and 4 (each within the scatter of the next, the first and the last beyond it).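

In this assay, the change from 4-chlorophenyl to 4-fluorophenyl gives a 6.6-fold higher number from compound 3 to compound 4 (0.82 log units; beyond the scatter), so the outcome at this aromatic carbon depends on which halogen is present, and a halogen as such does not secure the lower number. Fluoro and ethyl do not separate at this carbon, as a 2.0-fold higher number from compound 2 to compound 4 (0.30 log units; within the scatter) stays within the scatter, whereas chloro stands apart from both, with a 3.3-fold lower number from compound 2 to compound 3 (0.51 log units; beyond the scatter) as its step from ethyl; among these three groups, only chloro gives a distinct result, though three groups at a single position make a narrow basis for any pattern. Nothing available explains why chloro and fluoro differ here.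

Still open, going by these compounds, is whether bromo, methoxy or trifluoromethyl at this carbon would group with chloro or with fluoro and ethyl, which would show whether chloro is an isolated case or part of a broader trend. It is also unresolved whether the same exchange of chloro for fluoro would produce a step of similar size on a compound carrying the dimethylaminoethyl amine side chain of compound 1 in place of the ethylpiperazine.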